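Working notes on the series: the step to compound 3

This account rests on a few compounds, and the source may have more. Where it says the series, first, only, none or still open, it means among the compounds named here.

Two members of the series have so far been read in an ADME assay on J774 cells (Mus musculus) for cytotoxicity, read by MTT assay, with a stated time of 48 h, tested at 150 ug/mL; on this read-out higher numbers stand for a weaker effect at the one concentration tested and lower numbers for a stronger effect. Compound 1 `O=C(N/N=C/c1ccccc1Cl)c1cnccn1` gives 69% in this assay, and compound 2 `O=C(N/N=C/c1ccc(Br)cc1)c1cnccn1` gives 94% in this assay. Compound 2 thus stands highest of the two numbers on hand; the nearest number, that of compound 1, lies lower by a gap that is beyond the usual scatter.

Among the compounds with values here, no pair of measured compounds differs in a single place, so no measured step of one change is available to lean on. Compound 3 `N#Cc1ccc(/C=N/NC(=O)c2cnccn2)cc1` is still to be measured in this assay. Against compound 2 the change is cyano in place of bromo on an aromatic carbon. With nothing measured for this kind of change in the series, the expectation rests on compound 2 alone, and the step of a number 5 percentage points lower from compound 2 to compound 3 (within the scatter) is expected to remain within the scatter rather than to move clearly in either direction. Compound 3 is accordingly estimated at 89% in this assay, with a range from 74% to 100%.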

Compound 3, a percentage reported as activity, at one concentration (the size of the read-out at that concentration, not a potency): 100%
Estimate against measurement, compound 3: 11 percentage points below; the measured number falls inside the stated range.
By their numbers in this assay, from the lowest: compound 1; then compounds 2 and 3 (each within the scatter of the next).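

In this assay, the series now has its first step with a single change: cyano in place of bromo on an aromatic carbon, para to a large group, gives a number 6 percentage points higher from compound 2 to compound 3 (within the scatter). At this position, the read-out therefore does not separate the two groups, even though the entering cyano carries a hydrogen-bond acceptor and the leaving bromo does not. No measured evidence on hand accounts for this result.

This single step cannot show whether the position tolerates substituents generally, as it covers only bromo and cyano. As far as these compounds go, whether an amine, a carboxylic acid or a longer chain at the same position would also stay within the scatter of compound 2 remains open, as does the effect of moving cyano elsewhere on the ring.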